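Phenoxy substituent exchange: iodo to cyano

The source may report more compounds than this note shows. Statements on the series, on what has been measured and on what is new or still open speak of the compounds shown alone.

Compound 3 `N[C@@H](COP(=O)(O)OCCCOC(=O)CCc1ccccc1OCc1cccc(Oc2ccc(I)cc2)c1)C(=O)O` carries iodo on the phenoxy ring, and in an assay on cells for agonist activity at probable G-protein coupled receptor 34 (Mus musculus), with a stated time of 1 h (on this read-out higher numbers stand for larger maximal responses and lower numbers for smaller maximal responses), compound 3 gives 19.1%. Within the three measured compounds it sits second highest of three numbers, but every neighbour lies within the scatter: compound 1 `N[C@@H](COP(=O)(O)OCCCOC(=O)CCc1ccccc1OCc1cccc(Oc2ccccc2Cl)c1)C(=O)O` gives 19.8% and compound 2 `N[C@@H](COP(=O)(O)OCCCOC(=O)CCc1ccccc1OCc1cccc(Oc2ccc(Br)cc2)c1)C(=O)O` gives 17.7%, with a number 0.7 percentage points lower from compound 1 to compound 3 (within the scatter) and a number 1.4 percentage points higher from compound 2 to compound 3 (within the scatter), and between the other two a number 2.1 percentage points lower from compound 1 to compound 2 (within the scatter). Nothing in the set separates one halogenated phenoxy variant from another.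

Compound 4 `N#Cc1ccc(Oc2cccc(COc3ccccc3CCC(=O)OCCCOP(=O)(O)OC[C@H](N)C(=O)O)c2)cc1` is the next member: cyano in place of iodo on an aromatic carbon. The measured steps that bear on this change are the three halogen exchanges on the phenoxy ring, all of which are within the scatter. For the measured compounds named here, no measured step involves a cyano group, so its effect in this assay is unsupported by data; what the data show is that varying the substituent on that ring, across chloro, bromo and iodo and across two ring positions, has left the maximal response flat.

For compound 4 the expected step is therefore a number 0.1 percentage points lower from compound 3 to compound 4 (within the scatter), none beyond the scatter. As far as these compounds go, the estimate for compound 4 in this assay is 19%, with a range from 9% to 29%, the wider range reflecting that cyano is untested here.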

Compound 4, largest response reached (Emax), in percent of the reference or control that the assay uses: 18.3%
Estimate against measurement, compound 4: 0.7 percentage points above; low and high end bracket the measured number.
By their numbers in this assay, from the lowest: compounds 2, 4, 3 and 1 (each within the scatter of the next).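

Cyano is the first group on this aromatic carbon, para to a large group, that is not a halogen, and in this assay the exchange for iodo gives a number 0.8 percentage points lower from compound 3 to compound 4 (within the scatter). The comparisons with the other two halogenated compounds read the same way, with a number 0.6 percentage points higher from compound 2 to compound 4 (within the scatter) and a number 1.5 percentage points lower from compound 1 to compound 4 (within the scatter), so the flat maximal response now holds across all four compounds and includes a substituent of two heavy atoms with a triple bond and a hydrogen-bond acceptor, where the halogens have none. No supporting measurement bears on why the response stays level through this exchange.

Still open, as far as these compounds go, is whether an amine or a carboxylic acid on this aromatic carbon, or a longer chain in the same place, would move the maximal response beyond the scatter. These numbers also speak only to the largest response reached in this assay, and they leave open how the four compounds compare in the concentration needed to reach it.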